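Replacing the 2-oxopiperidin-1-yl amide: notes toward compound 4

This account rests on a few compounds, and the source may have more. Where it says the series, first, only, none or still open, it means among the compounds named here.

Compound 1 `Nc1sc(-c2ccc(Cl)cc2)c(-c2ccc(Cl)cc2)c1C(=O)N1CCCCC1=O` carries a 2-oxopiperidin-1-yl group on the carbonyl carbon of the shared core. For the measured compounds named here, in a functional assay on PC-3 cells (Homo sapiens) for inhibition, read by sulforhodamine B assay, with a stated time of 72 h (a higher number here means a weaker inhibitor, a lower number a stronger inhibitor), compound 1 gives 4940 nM, the lowest of the three numbers measured so far, though its gap to compound 2 is within the scatter. Compound 2 `CC1CCN(C(=O)c2c(N)sc(-c3ccc(Cl)cc3)c2-c2ccc(Cl)cc2)CC1` gives 5750 nM in this assay, and compound 3 `Nc1sc(-c2ccc(Cl)cc2)c(-c2ccc(Cl)cc2)c1C(=O)NC1CCC1` gives 24800 nM.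

Going by the values given here, two measured steps bear on the change from compound 1 to compound 4 `CN1CCN(C(=O)c2c(N)sc(-c3ccc(Cl)cc3)c2-c2ccc(Cl)cc2)CC1`: 4-methylpiperazin-1-yl in place of 2-oxopiperidin-1-yl on a carbonyl carbon. The exchange of the 2-oxopiperidin-1-yl group for a different six-membered ring on the carbonyl carbon was a 1.2-fold higher number from compound 1 to compound 2 (0.07 log units; within the scatter), whereas opening the ring to a cyclobutylamino group was a 5.0-fold higher number from compound 1 to compound 3 (0.70 log units; beyond the scatter). Compound 4 keeps a six-membered ring attached through ring nitrogen to the carbonyl carbon, as compounds 1 and 2 do, so the nearer precedent is the step to compound 2, and no step beyond the scatter is expected.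

The estimate for compound 4 in this assay is therefore 6000 nM, with a range from 2500 nM to 15000 nM, which corresponds to an expected step of a 1.2-fold higher number from compound 1 to compound 4 (0.08 log units; within the scatter).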

Compound 4, half-maximal inhibitory concentration: 13100 nM
Estimate against measurement, compound 4: 2.2-fold (0.34 log units) below; the range from low to high includes it.
By their numbers in this assay, from the lowest: compounds 1 and 2 (each within the scatter of the next); then compounds 4 and 3 (each within the scatter of the next).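

Six-membered ring attachment through nitrogen on the carbonyl carbon does not by itself keep the number in the range of compounds 1 and 2 in this assay: 4-methylpiperazin-1-yl in place of 2-oxopiperidin-1-yl gives (a 2.7-fold higher number from compound 1 to compound 4 (0.42 log units; beyond the scatter)), and the closer comparison, 4-methylpiperazin-1-yl in place of 4-methylpiperidin-1-yl, gives (a 2.3-fold higher number from compound 2 to compound 4 (0.36 log units; beyond the scatter)). The ring group therefore matters at this position beyond its size and its attachment, and compound 4 is not separated from the cyclobutylamino amide (a 1.9-fold lower number from compound 3 to compound 4 (0.28 log units; within the scatter)), so a six-membered ring and an open secondary amide can read alike here. Nothing measured on these compounds accounts for either step.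

A piperazin-1-yl group with hydrogen in place of the methyl, or a morpholin-4-yl group, on the same carbonyl carbon would show whether the step follows the second ring nitrogen or the methyl on it. From the compounds shown here alone, whether a longer chain on that ring nitrogen, or a carboxylic acid on the ring, moves the number in either direction remains open.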